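Swapping the amide cap: from benzothiophene to a trifluoromethyl cinnamoyl

The source may report more compounds than this note shows. Statements on the series, on what has been measured and on what is new or still open speak of the compounds shown alone.

In a functional assay on BGC-823 cells (Homo sapiens) for cytotoxicity, read by MTT assay, with a stated time of 72 h (on this read-out higher numbers stand for weaker inhibition and lower numbers for stronger inhibition), compound 1 `CCc1ccc(C(=O)NC[C@H]2c3[nH]c4ccccc4c3C[C@H]3[C@H]4c5[nH]c6ccccc6c5C[C@@H]([C@H](C#N)N23)N4C)cc1` gives 660 nM. Compound 2 `CN1[C@@H]2c3[nH]c4ccccc4c3C[C@H]1[C@H](C#N)N1[C@@H](CNC(=O)c3cc4ccccc4s3)c3[nH]c4ccccc4c3C[C@@H]21` gives 240 nM in this assay, the lowest of the two numbers, reached by a 2.8-fold lower number from compound 1 to compound 2 (0.44 log units; beyond the scatter). Compound 3 `CN1[C@@H]2c3[nH]c4ccccc4c3C[C@H]1[C@H](C#N)N1[C@@H](CNC(=O)/C=C/c3cccc(C(F)(F)F)c3)c3[nH]c4ccccc4c3C[C@@H]21` differs from compound 2 by 2-(3-(trifluoromethyl)phenyl)ethenyl in place of 1-benzothiophen-2-yl on a carbonyl carbon. Within the data shown here, the only step that bears on it is the one from compound 1 to compound 2, which changed the same cap and was modest, so a change of similar or smaller size, in either direction, is expected here. Compound 3 is expected to give about 400 nM, within 150 nM to 1100 nM. That amounts to an expected step of a 1.7-fold higher number from compound 2 to compound 3 (0.22 log units; within the scatter).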

Compound 3, half-maximal inhibitory concentration: 910 nM
For compound 3 the middle estimate is 2.3-fold (0.36 log units) below the measured one; low and high end bracket the measured number.
By their numbers in this assay, from the lowest: compound 2; then compounds 1 and 3 (each within the scatter of the next).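

In this assay the cap on the carbonyl carbon can lose ground as well as gain it, with a 3.8-fold higher number from compound 2 to compound 3 (0.58 log units; beyond the scatter) as 2-(3-(trifluoromethyl)phenyl)ethenyl replaces 1-benzothiophen-2-yl. Against the 4-ethylphenyl cap, the new cap shows no real difference, with a 1.4-fold higher number from compound 1 to compound 3 (0.14 log units; within the scatter) on the same core. Nothing measured here explains why the benzothiophene cap stands apart.

Still open, going by these compounds, is whether a cap carrying an amine or a carboxylic acid on this carbonyl carbon would match compound 2. Also open, on these data alone, is whether the double bond or the trifluoromethyl group accounts for the loss.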